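The compounds below may be only part of what the source reports. "The series", "measured", "known", "first", "only" and "open" are said of these compounds alone.

Measured so far in a functional assay on KYSE-450 cells (Homo sapiens) for inhibition, read by CCK-8 assay, with a stated time of 48 h; a lower number here means a stronger inhibitor, a higher number a weaker inhibitor:
- compound 1 `COc1ccc(CN(C(=O)CSC(=S)N2CCN(C)CC2)c2cc(OC)c(OC)c(OC)c2)cc1`: 1250 nM
- compound 2 `CCN1CCN(CC(=O)N(Cc2ccc(OC)cc2)c2cc(OC)c(OC)c(OC)c2)CC1`: 16100 nM
- compound 3 `COc1cc(N(Cc2ccc(Cl)cc2)C(=O)CSC(=S)N2CCN(C(=O)OC(C)(C)C)CC2)cc(OC)c1OC`: 11900 nM

Compound 3 sits far above compound 1 and within the usual scatter of compound 2, so it is among the weaker inhibitors here. Compound 4 `COc1ccc(CN(C(=O)CSC(=S)N2CCN(C(=O)OC(C)(C)C)CC2)c2cc(OC)c(OC)c(OC)c2)cc1N=[N+]=[N-]` carries 3-azido-4-methoxyphenyl in place of 4-chlorophenyl on a saturated chain carbon bound to an amide-type nitrogen.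

For the measured compounds named here, no measured step changes this group. Going by the values given here, the only measured step, a 13-fold higher number from compound 1 to compound 2 (1.11 log units; beyond the scatter), lies at another place, on a saturated chain carbon bound to a carbonyl carbon. It therefore gives no direct size, though it shows that a single change can matter a great deal. Compound 1 also has a methoxy on its benzyl group and reads 1250 nM, but compound 2 has one too and reads 16100 nM, so this is weak support for improvement.

A modest move towards a lower number is expected, a 1.7-fold lower number from compound 3 to compound 4 (0.23 log units; within the scatter). The estimated value for compound 4 is 7000 nM, with an expected range of 1800 nM to 25000 nM.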

Compound 4, half-maximal inhibitory concentration: 840 nM
Estimate against measurement, compound 4: 8.3-fold (0.92 log units) above, and the stated range ends above it.
By their numbers in this assay, from the lowest: compounds 4 and 1 (each within the scatter of the next); then compounds 3 and 2 (each within the scatter of the next).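

Moving from 4-chlorophenyl to 3-azido-4-methoxyphenyl on a saturated chain carbon bound to an amide-type nitrogen gives, in this assay, a 14-fold lower number from compound 3 to compound 4 (1.15 log units; beyond the scatter) and is the first measured change at this place. For the compounds shown here, it shows that this place, and not only the one changed in a 13-fold higher number from compound 1 to compound 2 (1.11 log units; beyond the scatter), can shift the number far beyond the scatter. The azido and the methoxy enter together, so the step belongs to the pair of them, and nothing measured here explains the drop.

As far as these compounds go, how much of the step comes from the azido and how much from the methoxy remains open. Also open, from the compounds shown here alone, is how the number would respond to an amine or a nitrile in place of the azido on this ring.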